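Swapping one chloro for hydrogen in compound 1

The compounds below may be only part of what the source reports. "The series", "measured", "known", "first", "only" and "open" are said of these compounds alone.

Compound 1 (`C=C(c1ccc(Cl)c(Cl)c1Cl)C1COC2(CCCC2)OO1`) 690 nM
Compound 2 (`C=C(c1ccc(Cl)cc1Cl)C1COC2(CCCC2)OO1`) 1430 nM

In a functional assay on A549 cells (Homo sapiens) for inhibition, read by MTT assay, with a stated time of 72 h (on this read-out higher numbers stand for weaker inhibition and lower numbers for stronger inhibition), compound 1 has the lower of the two numbers, making it the stronger inhibitor of this pair. Compound 3 (`C=C(c1ccc(Cl)c(Cl)c1)C1COC2(CCCC2)OO1`) is still unmeasured, and it differs from compound 1 as follows: hydrogen in place of chloro on an aromatic carbon. Among the measured compounds shown here, the only measured step of this type is modest (a 2.1-fold higher number from compound 1 to compound 2 (0.32 log units; beyond the scatter)) and takes away a different chloro, so it is a limited guide. A similar modest rise is expected, the estimated step being a 1.9-fold higher number from compound 1 to compound 3 (0.28 log units; within the scatter) in this measurement. Compound 3 is estimated at 1300 nM with an expected range of 550 nM to 3000 nM here.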

Compound 3, half-maximal inhibitory concentration: 4680 nM
Estimate against measurement, compound 3: 3.6-fold (0.56 log units) below; the measured number lies above the stated range.
By their numbers in this assay, from the lowest: compound 1; then compound 2; then compound 3.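

In this assay, removing a chloro from compound 1 does not always cost the same: taking away the one ortho to a large group gives a 6.8-fold higher number from compound 1 to compound 3 (0.83 log units; beyond the scatter), against a 2.1-fold higher number from compound 1 to compound 2 (0.32 log units; beyond the scatter) for the other removal. The chlorines of compound 1 are therefore not interchangeable, and the size of the loss depends on which one leaves. No measurement here explains this difference. On these data alone, it remains open whether a methyl or methoxy group at this position could keep the number close to that of compound 1, or whether only chloro does so.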